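Swapping a fluorine-bearing benzyl group for a chlorinated one

The source may report more compounds than this note shows. Statements on the series, on what has been measured and on what is new or still open speak of the compounds shown alone.

Measured in a functional assay on RS4-11 cells (Homo sapiens) for inhibition, read by CCK-8 assay, with a stated time of 48 h, tested at 20 uM; on this read-out higher numbers stand for more inhibition of growth at the one concentration tested and lower numbers for less inhibition of growth:
compound 1 `COc1ccc(Cc2nnc(NC(=O)/C(C#N)=C/c3ccccc3OS(=O)(=O)c3ccc(OC)cc3)s2)cc1`: 78%
compound 2 `COc1ccc(S(=O)(=O)Oc2ccccc2/C=C(\C#N)C(=O)Nc2nnc(Cc3ccc(F)cc3)s2)cc1`: 76%
compound 3 `COc1ccc(S(=O)(=O)Oc2ccccc2/C=C(\C#N)C(=O)Nc2nnc(Cc3cccc(F)c3)s2)cc1`: 74%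

In this assay, compound 3 gives 74%, which lies within the usual scatter of the values for the other two compounds. Going by the values given here, the next compound, compound 4 `COc1ccc(S(=O)(=O)Oc2ccccc2/C=C(\C#N)C(=O)Nc2nnc(Cc3ccc(Cl)cc3)s2)cc1`, keeps the shared core and alters only one group. Here 4-chlorophenyl stands in place of 3-fluorophenyl on a saturated chain carbon bound to an aromatic carbon: 4-chlorophenyl in place of 3-fluorophenyl on a saturated chain carbon bound to an aromatic carbon.

Among the compounds with values here, no measured compound carries the 4-chlorophenyl group, so the closest evidence comes from other changes at this same end of the molecule. Exchanging 4-fluorophenyl for 3-fluorophenyl gave a number 2 percentage points lower from compound 2 to compound 3 (within the scatter). Fluoro in place of methoxy gave a number 2 percentage points lower from compound 1 to compound 2 (within the scatter), and 3-fluorophenyl in place of 4-methoxyphenyl gave a number 4 percentage points lower from compound 1 to compound 3 (within the scatter). All three steps are small, so no step beyond the scatter is expected here. The expected step is a number 2 percentage points higher from compound 3 to compound 4 (within the scatter). The estimated value for compound 4 is 76%, with an expected range from 66% to 86%.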

Compound 4, percent growth inhibition at one concentration: 77%
Compound 4: the middle estimate sits 1 percentage points below what was measured; the range from low to high includes it.
By their numbers in this assay, from the lowest: compounds 3, 2, 4 and 1 (each within the scatter of the next).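

In this assay the 4-chlorophenyl group on this saturated chain carbon gives a result in line with the earlier groups, whichever comparison is read: 4-chlorophenyl in place of 3-fluorophenyl gives (a number 3 percentage points higher from compound 3 to compound 4 (within the scatter)), chloro in place of fluoro gives (a number 1 percentage points higher from compound 2 to compound 4 (within the scatter)), and chloro in place of methoxy gives (a number 1 percentage points lower from compound 1 to compound 4 (within the scatter)). The earlier compounds shown here covered only fluoro and methoxy on this aromatic ring, so chloro widens the set of exchanges at this end of the molecule, and across these four compounds none of them produces a step beyond the scatter. Nothing available here explains why these exchanges change the number so little.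

A reading at one concentration also leaves open whether these four compounds would separate at lower concentrations, where a difference hidden at this single dose could appear. As far as these compounds go, it also remains open whether a different kind of group, such as an amine or a carboxylic acid on this aromatic ring, or a longer chain in place of the benzyl group, would move the number beyond the scatter.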